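Swapping a sulfated side chain for a cyclohexyl ring

The source may report more compounds than this note shows. Statements on the series, on what has been measured and on what is new or still open speak of the compounds shown alone.

Three sulfated sugar derivatives have been examined in an assay on isolated protein for binding affinity to vascular endothelial growth factor A, long form (Homo sapiens), read by surface plasmon resonance; a lower number here means tighter binding, a higher number weaker binding. Compound 1 `CO[C@H]1O[C@H](CNC(=O)CN(Cc2ccccc2)C(C)=O)[C@@H](OS(=O)(=O)O)[C@H](OS(=O)(=O)O)[C@@H]1OS(=O)(=O)O` gives 77000 nM. Compound 2 `CO[C@H]1O[C@H](CNC(=O)CN(CCOS(=O)(=O)O)C(C)=O)[C@@H](OS(=O)(=O)O)[C@H](OS(=O)(=O)O)[C@@H]1OS(=O)(=O)O` gives 280000 nM, the highest of the three numbers and therefore the weakest binder in this set. Compound 3 `CCN(CC(=O)NCCO[C@H]1O[C@H](COS(=O)(=O)O)[C@@H](OS(=O)(=O)O)[C@H](OS(=O)(=O)O)[C@@H]1OS(=O)(=O)O)C(=O)CCCCCCCCCOS(=O)(=O)O`, built on a differently linked sugar, gives 50000 nM.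

For the measured compounds named here, the only single-point step measured so far is a 3.6-fold higher number from compound 1 to compound 2 (0.56 log units; beyond the scatter). Compound 4 `CO[C@H]1O[C@H](CNC(=O)CN(C(C)=O)C2CCCCC2)[C@@H](OS(=O)(=O)O)[C@H](OS(=O)(=O)O)[C@@H]1OS(=O)(=O)O` is compound 2 with one change: cyclohexyl in place of 2-(sulfooxy)ethyl on an amide-type nitrogen. This largely reverses the earlier step, since the sulfated chain on the amide-type nitrogen leaves and a carbon-only ring, reminiscent of the phenyl of compound 1, takes its place. On that basis the number is expected to fall, by roughly the size seen in the measured step, landing near compound 1. The estimated step is a 4.0-fold lower number from compound 2 to compound 4 (0.60 log units; beyond the scatter). Compound 4 is therefore expected to give about 70000 nM in this assay, with a plausible range from 25000 nM to 200000 nM.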

Compound 4, dissociation constant: 1700000 nM
Estimate against measurement, compound 4: 24-fold (1.39 log units) below; the whole stated range lies below it.
By their numbers in this assay, from the lowest: compounds 3 and 1 (each within the scatter of the next); then compound 2; then compound 4.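

In this assay, placing cyclohexyl on the amide-type nitrogen in place of 2-(sulfooxy)ethyl gives a 6.1-fold higher number from compound 2 to compound 4 (0.78 log units; beyond the scatter), so here a carbon-only ring does not stand in for the benzyl of compound 1. The direct comparison, cyclohexyl in place of benzyl, gives a 22-fold higher number from compound 1 to compound 4 (1.34 log units; beyond the scatter) and is the largest step in this set, showing that binding at this position depends strongly on which ring-bearing group is present. Nothing available explains this difference between benzyl and cyclohexyl.

Still open, on these data alone, is how phenyl attached directly to the amide-type nitrogen, or cyclohexylmethyl, would read on the same core, which would help separate the effect of the ring type from that of the methylene link in benzyl. As far as these compounds go, a carboxylic acid at the end of the chain, in place of the sulfate of compound 2, also remains open.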